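The compounds below may be only part of what the source reports. "The series", "measured", "known", "first", "only" and "open" are said of these compounds alone.

Measured compounds:
- compound 1, `COc1cc(C)cc(-c2c(-c3ccnc(-c4ccc(N(C)C)cc4)c3)cnn2CC#N)c1`: 89%
- compound 2, `COc1cc(C)cc(-c2nn(CC#N)cc2-c2ccnc(-c3ccc(N(C)C)cc3)c2)c1`: 90%

Both measured compounds share the same core and were tested in a functional assay on UACC-257 cells (Homo sapiens) for cytotoxicity, read by sulforhodamine B assay, with a stated time of 48 h, tested at 0.001 uM; on this read-out lower numbers stand for a stronger effect and higher numbers for a weaker effect at the one concentration tested. In this assay compound 1 gives 89%, and compound 2 gives 90%. Compound 1 has the lowest of the two numbers, but its distance to compound 2 lies within the scatter, so the two cannot be told apart. Both sit near the top of the scale, which here means only a small effect at the single concentration tested.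

Compound 3, `COc1cc(C)cc(-c2c(-c3ccnc(-c4ccc(C(C)=O)cc4)c3)cnn2CC#N)c1`, is the next compound of interest. Compared with compound 1 its change is acetyl in place of dimethylamino on an aromatic carbon. Among the compounds with values here, no step between measured compounds shows what this kind of change does in this assay, so the only guide is that both measured compounds lie close to the top of the scale. On that basis the step is expected to be small: a number 1 percentage points lower from compound 1 to compound 3 (within the scatter) is expected to stay within the scatter, with no clear direction. Compound 3 is therefore estimated at 88%, with a likely range from 74% to 100%.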

Compound 3, a percentage reported as activity, at one concentration (the size of the read-out at that concentration, not a potency): 95%
For compound 3 the middle estimate is 7 percentage points below the measured one; the measured number falls inside the stated range.
By their numbers in this assay, from the lowest: compounds 1, 2 and 3 (each within the scatter of the next).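

In this assay, exchanging dimethylamino for acetyl on an aromatic carbon, para to a large group, gives a number 6 percentage points higher from compound 1 to compound 3 (within the scatter), so the two compounds cannot be told apart at the one concentration tested. Within the data shown here, this is the first direct reading of any change at this position, and it shows that this exchange, from 4-(dimethylamino)phenyl to 4-acetylphenyl, gives no clear difference in the read-out, although nitrogen gives way to oxygen and a double bond enters outside the aromatic rings. A single exchange between two groups of equal heavy-atom count cannot show whether this position matters in general, and nothing measured here offers an explanation for the result.

The compounds shown leave open whether a carboxylic acid, a primary amine or a longer chain in this place would stand apart from dimethylamino and acetyl, and whether the same exchange would read alike on the core of compound 2. They also leave open how compound 1 and compound 3 compare at higher concentrations, where a larger effect could separate them.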